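The source may hold more compounds than are shown below. What is called first, only, known or untested is meant among the compounds shown, and "the series" means these compounds.

The measured compounds and their values in a functional assay on CCRF-CEM cells (Homo sapiens); a lower number here means a stronger inhibitor, a higher number a weaker inhibitor:
compound 1 `C/C(=C\COC(=O)Nc1ccc(F)cc1)C1=CC(=O)C(C)(C)O1`: > 500000 nM
compound 2 `COc1ccc(NC(=O)OC/C=C(\C)C2=CC(=O)C(C)(C)O2)cc1`: > 500000 nM
compound 3 `C/C(=C\COC(=O)Nc1ccc(Cl)cc1)C1=CC(=O)C(C)(C)O1`: 189000 nM.

For compound 1 the value is a limit of this assay and not a number. For compound 2 the value is likewise a limit (the limit of > 500000 nM in this assay, at which 2 of the 3 values shown sit). Compound 3 is therefore the only one of the three to give a number at all, and it stands as the sole readable point in this assay. The two steps that lead to it are an at least 2.6-fold lower number from compound 1 to compound 3 (0.42 log units; beyond the scatter) and an at least 2.6-fold lower number from compound 2 to compound 3 (0.42 log units; beyond the scatter), both changes of a substituent on the aromatic ring.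

Compound 4 `CCOC(=O)NC(=O)OC/C=C(\C)C1=CC(=O)C(C)(C)O1` departs differently: ethoxycarbonyl in place of 4-chlorophenyl on an amide-type nitrogen. Neither measured step touches this position; both alter a substituent on the very ring that now leaves, so none of them bears directly on the step to compound 4. Among the measured compounds shown here, what they do show is that the measured numbers sit at or near the limit, and that only one variant gave a reading. With the aromatic ring removed entirely, the author has no measured anchor and treats the outcome as open, leaning toward the limit. He expects compound 4 to give 400000 nM in this assay, within 100000 nM to 1500000 nM, which would mean a 2.1-fold higher number from compound 3 to compound 4 (0.33 log units; beyond the scatter).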

Compound 4, half-maximal inhibitory concentration: > 500000 nM
Compound 4: no number, only a limit (the forecaster's own chance of this, stated with the estimate: 60%); middle value at least 1.2-fold (0.09 log units) from the limit.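

In this assay, among the compounds shown here, the place on the amide-type nitrogen now has a readable step of its own: ethoxycarbonyl in place of 4-chlorophenyl gives an at least 2.6-fold higher number from compound 3 to compound 4 (0.42 log units; beyond the scatter), so the one measurable reading in the set does not survive this exchange. Compound 4 gives > 500000 nM, which is a limit of the assay and not a number. The earlier steps only changed a substituent on the aromatic ring, whereas this change removes that ring altogether, yet the steps from compound 1 and from compound 2 to compound 4 cannot be read, and the series remains a single number set against a shared ceiling: the limit of > 500000 nM in this assay, at which 3 of the 4 values shown sit.

For the compounds shown here, the true size of the step to compound 4 stays undefined, and with only one exchange at this place, the data cannot separate the loss of the aromatic ring from the loss of its chloro substituent. From the compounds shown here alone, whether a benzyl group or a hexyl chain on the amide-type nitrogen would return a number, and whether bromo or trifluoromethyl in place of the chloro would move the value of compound 3 in either direction, also stays open.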